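The compounds below may be only part of what the source reports. "The series", "measured", "known", "first", "only" and "open" are said of these compounds alone.

Of the compounds shown here, three that share one core have so far been tested in a physicochemical assay for solubility, read by spectrophotometry, in phosphate buffer, with a stated time of 2 h, at pH 7.4; a lower number here means a less soluble compound, a higher number a more soluble compound. Compound 1 `COc1ccc2[nH]c(C(=O)N3CC(=O)N(Cc4ccccc4)[C@@H](CCc4ccccc4)C3)cc2c1` gives 4400 nM, compound 2 `COc1cccc(CN2C(=O)CN(C(=O)c3cc4cc(OC)ccc4[nH]3)C[C@@H]2COCc2ccccc2)c1` gives 11700 nM, and compound 3 `COc1ccc2[nH]c(C(=O)N3CC(=O)N(Cc4ccccc4)[C@@H](COCc4ccccc4)C3)cc2c1` gives 8800 nM. Compound 3 therefore stands in a tight group, with neither of the other two separated from it by more than the usual scatter of repeated measurements.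

The next compound, compound 4 `COc1ccc2[nH]c(C(=O)N3CC(=O)N(Cc4ccccc4)[C@@H](CCN4CCC5(CC4)CC5)C3)cc2c1`, alters compound 3 on a saturated chain carbon bound to a saturated ring carbon: a group of 9 heavy atoms (8 carbon, 1 nitrogen; one three-membered non-aromatic ring of carbon only, one six-membered non-aromatic ring with 1 hetero atom) in place of a group of 8 heavy atoms (7 carbon, 1 oxygen; one six-membered aromatic ring of carbon only), on a saturated chain carbon bound to a saturated ring carbon.

Within the data shown here, two measured steps bear on this. The closer one, at the same place, is benzyloxy in place of benzyl, which gave a 2.0-fold higher number from compound 1 to compound 3 (0.30 log units; within the scatter). The other, hydrogen in place of methoxy on an aromatic carbon, gave a 1.3-fold lower number from compound 2 to compound 3 (0.12 log units; within the scatter). Neither step removes a six-membered aromatic ring of carbon only or brings in a six-membered non-aromatic ring with 1 hetero atom, so the measurements give no direct reading of this larger exchange.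

An upward move is expected, but this is a judgement from the structural change alone, and the uncertainty is wide. The estimated change is a 2.5-fold higher number from compound 3 to compound 4 (0.40 log units; beyond the scatter). For compound 4 the expected value is 22000 nM, with an estimated range from 7000 nM to 80000 nM.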

Compound 4, solubility: > 25000 nM
Compound 4 ended at the assay's limit; the forecaster's own chance of this, stated with the estimate: 15%; middle value at least 1.1-fold (0.05 log units) from the limit.
By their numbers in this assay, from the lowest: compounds 1, 3 and 2 (each within the scatter of the next, the first and the last beyond it). At a limit, above all of these: compound 4.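

In this assay compound 4 gives > 25000 nM, which is a limit of the assay and not a number: the limit of > 25000 nM in this assay, at which 1 of the 4 values shown sits.

This position on a saturated chain carbon bound to a saturated ring carbon had so far shown only a step within the scatter, and the new exchange goes further, with an at least 2.8-fold higher number from compound 3 to compound 4 (0.45 log units; beyond the scatter). Taking the comparison back to the benzyl-bearing side chain gives an at least 5.6-fold higher number from compound 1 to compound 4 (0.75 log units; beyond the scatter), so both steps that end at compound 4 lie beyond the scatter, and the group with one three-membered non-aromatic ring of carbon only and one six-membered non-aromatic ring with 1 hetero atom is the first change here to separate two compounds clearly.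

The exchange removes a six-membered aromatic ring of carbon only and brings in the nitrogen and both new rings together, so the compounds shown cannot say which of these parts accounts for the step. Also open, on these data alone, is how a simple open-chain amine such as dimethylamino, or a carboxylic acid, would read at the end of the same chain.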